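The compounds below may be only part of what the source reports. "The series", "measured", "known", "first", "only" and "open" are said of these compounds alone.

Compound 1, `CC(CC(=O)O)CC(=O)c1ccc(Oc2ccccc2)cc1`: in an assay (strain CD) for inhibition of 3-hydroxy-3-methylglutaryl-coenzyme A reductase (Rattus norvegicus), read by scintillation counting, using microsomes, with a stated time of 90 min (on this read-out lower numbers stand for stronger inhibition and higher numbers for weaker inhibition), compound 1 gives 850000 nM. Compound 2, `CC(CC(=O)O)CC(=O)c1ccc(Sc2ccccc2)cc1`: compound 2 gives 570000 nM. Compound 3, `CC(CCc1ccc(Oc2ccccc2)cc1)CC(=O)O`: compound 3 gives 30000 nM.

The difference between the core of compound 1 and the core of compound 3 is not broken down here; compound 3 stands at the lowest of the three numbers, beyond the scatter from the other two. Between compound 1 and compound 2 the change is phenylsulfanyl in place of phenoxy on an aromatic carbon, and it brought a 1.5-fold lower number from compound 1 to compound 2 (0.17 log units; within the scatter). Compound 4, `CC(CCc1ccc(Sc2ccccc2)cc1)CC(=O)O`, carries the same kind of change on the core of compound 3: phenylsulfanyl in place of phenoxy on an aromatic carbon, the place being para to a group of 8 heavy atoms rather than 9. A step of a 1.5-fold lower number from compound 3 to compound 4 (0.18 log units; within the scatter) is expected, since the earlier pair showed a 1.5-fold lower number from compound 1 to compound 2 (0.17 log units; within the scatter). Compound 4 is therefore estimated at 20000 nM.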

Compound 4, half-maximal inhibitory concentration: 40000 nM
Beside the measured number, compound 4's estimate is 2.0-fold (0.30 log units) below it; the range from low to high includes it.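

In this assay, phenylsulfanyl in place of phenoxy on an aromatic carbon gave a 1.3-fold higher number from compound 3 to compound 4 (0.12 log units; within the scatter), so on this core too the change moved the number no further than the scatter. Set beside the earlier step, the new one shows no difference between the two cores: the same change on two cores in this assay, a 1.5-fold lower number (0.17 log units; within the scatter) from compound 1 to compound 2 and a 1.3-fold higher number (0.12 log units; within the scatter) from compound 3 to compound 4, 2.0-fold (0.30 log units) apart, within the scatter of two such steps This shows that the change stayed small on both cores, but neither step gives it a direction, and two cores say nothing about how it would behave on any other.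

The compounds shown leave open whether an amine nitrogen in place of the oxygen or sulfur would stay as close. They also leave open whether this holds with a chlorine on the terminal phenyl ring or a longer chain bearing the carboxylic acid.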